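The source may hold more compounds than are shown below. What is called first, only, known or untested is meant among the compounds shown, and "the series" means these compounds.

In a functional assay on the whole organism for inhibition, with Rattus norvegicus as the target (on this read-out lower numbers stand for an effect already at smaller amounts and higher numbers for an effect only at larger amounts of compound), compound 1 `CC1CCC(=NNc2ccccc2)c2ncc(C(=O)O)c(=O)n21` gives 1.2 umol/kg. Compound 2 `O=C(O)c1cnc2n(c1=O)CCC/C2=N\Nc1ccccc1` reaches only a limit of the assay, > 100 umol/kg. Compound 3 `CC1CC/C(=N\Nc2ccccc2Cl)c2ncc(C(=O)O)c(=O)n21` also gives only a limit, > 1000 umol/kg, so it sits at the limit of > 1000 umol/kg in this assay, at which 1 of the 3 values shown sits, and no true number for it is known. Compound 4 `CC1CC/C(=N\Nc2ccccc2I)c2ncc(C(=O)O)c(=O)n21` differs from compound 3 in one place: iodo in place of chloro on an aromatic carbon. Among the compounds with values here, no pair of measured compounds separated by a single change is available here, so the size of this step cannot be read from the measured compounds. The step that the limit leaves unreadable from compound 3 to compound 4 is expected to be no larger than the usual scatter, with compound 4 most likely again reported only as a limit. The estimate for compound 4 in this assay is 1500 umol/kg, between 300 umol/kg and 10000 umol/kg.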

Compound 4, dose for 50% inhibition: > 1000 umol/kg
Compound 4 gave a limit, no number; the forecaster's own chance of this, stated with the estimate: 80%; the middle value lies beyond the limit too.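

Within the data shown here, compound 3 and compound 4 both give only a limit in this assay, and no step from chloro to iodo can be read between them. As far as these compounds go, the true value of each compound, and any difference between them, stays open.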